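The source may hold more compounds than are shown below. What is called first, only, known or untested is meant among the compounds shown, and "the series" means these compounds.

Measured compounds in a functional assay on the whole organism (strain Wistar) for inhibition, with Rattus norvegicus as the target, read by paw edema, with a stated time of 1 h, at a dose of 10 mg/kg by the intraperitoneal route; on this read-out lower numbers stand for less inhibition and higher numbers for more inhibition at the one dose given (going by the name of the read-out):
compound 1, `O=C(N/N=C/c1ccccc1)c1cccnc1Nc1cccc(C(F)(F)F)c1`: 53.9%
compound 2, `O=C(N/N=C/c1ccc(F)cc1)c1cccnc1Nc1cccc(C(F)(F)F)c1`: 43.2%
compound 3, `O=C(N/N=C/c1ccc(Cl)cc1)c1cccnc1Nc1cccc(C(F)(F)F)c1`: 67.2%

Among these three, compound 3 stands highest in this assay, and both of its steps are beyond the scatter: a number 13.3 percentage points higher from compound 1 to compound 3 (beyond the scatter) and a number 24 percentage points higher from compound 2 to compound 3 (beyond the scatter). The third measured step runs the other way, a number 10.7 percentage points lower from compound 1 to compound 2 (beyond the scatter), so on this small set the chloro-bearing compound 3 sits clearly above the other two.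

Compound 4, `O=C(N/N=C/c1ccc(O)cc1)c1cccnc1Nc1cccc(C(F)(F)F)c1`, is the next compound in line. Its difference from compound 3 is hydroxy in place of chloro on an aromatic carbon.

The two measured steps that bear on this change are the ones into compound 3, a number 13.3 percentage points higher from compound 1 to compound 3 (beyond the scatter) and a number 24 percentage points higher from compound 2 to compound 3 (beyond the scatter), since both show what chloro added at this aromatic carbon; the step from compound 3 to compound 4 takes that chloro away again. Going by the values given here, no measured compound carries a hydroxy, so there is nothing in hand to say whether hydroxy restores any of that gain. The expectation is therefore a step down in this assay, of modest size and with wide uncertainty: a number 17.2 percentage points lower from compound 3 to compound 4 (beyond the scatter). For compound 4 the estimated value is 50%, expected to lie between 32% and 68%.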

Compound 4, a percentage reported as inhibition, in the whole organism at one dose (the size of the read-out at that dose, not a potency): 70.5%
Estimate against measurement, compound 4: 20.5 percentage points below; measured number above the stated range.
By their numbers in this assay, from the lowest: compound 2; then compound 1; then compounds 3 and 4 (each within the scatter of the next).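

In this assay, the change from 4-chlorophenyl to 4-hydroxyphenyl does not separate the two compounds (a number 3.3 percentage points higher from compound 3 to compound 4 (within the scatter)), so the higher reading at this place on the ring is not confined to chloro. Hydroxy also stands clear of both hydrogen (a number 16.6 percentage points higher from compound 1 to compound 4 (beyond the scatter)) and fluoro (a number 27.3 percentage points higher from compound 2 to compound 4 (beyond the scatter)), which gives this place a second group, sharing no heavy atom with chloro, that reads above compound 1 and compound 2. The hydrogen-bond donor and acceptor counted for hydroxy, against none for chloro, therefore bring no difference that this assay can resolve between compound 3 and compound 4, while fluoro in compound 2 shows that not every replacement of hydrogen here raises the number.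

Nothing available gives a reason for this order among the groups. As far as these compounds go, whether an amine, a methoxy group or a carboxylic acid at the same place would read with compound 3 and compound 4 or fall toward compound 2 remains open, as does whether these readings would hold at other doses and times.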